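Extending the substituent on the ring nitrogen of a benzimidazole-type antagonist

The source may hold more compounds than are shown below. What is called first, only, known or untested is meant among the compounds shown, and "the series" means these compounds.

The shared core carries an acid on one side and a substituted isoxazole ether on the other, and the two measured compounds differ only at the aromatic nitrogen. Compound 1 `CCn1c(-c2ccc(OCc3c(-c4c(Cl)cccc4Cl)noc3C(C)C)cc2)nc2ccc(C(=O)O)cc21` gives 5760 nM in an assay on HEK-293T cells for antagonist activity at vitamin D3 receptor (Homo sapiens), read by a luciferase reporter, with a stated time of 24 h (on this read-out higher numbers stand for weaker inhibition and lower numbers for stronger inhibition), and compound 2 `CC(C)c1onc(-c2c(Cl)cccc2Cl)c1COc1ccc(-c2nc3ccc(C(=O)O)cc3n2C2CC2)cc1` gives 3200 nM. The step of a 1.8-fold lower number from compound 1 to compound 2 (0.26 log units; within the scatter) is the only one measured here, so compound 2 shows the lowest of the two numbers while sitting within the scatter of compound 1. Compound 3 `CCCC(CCC)n1c(-c2ccc(OCc3c(-c4c(Cl)cccc4Cl)noc3C(C)C)cc2)nc2ccc(C(=O)O)cc21` carries the change (1-propylbutyl in place of cyclopropyl on an aromatic nitrogen). For the measured compounds named here, the single step that bears on it, a 1.8-fold lower number from compound 1 to compound 2 (0.26 log units; within the scatter), changed little, so the expected step of no change at the digits printed from compound 2 to compound 3 (within the scatter) is none beyond the scatter, with a wide range because no measured compound carries a chain of this size. Compound 3 is expected to give about 3200 nM, between 1000 nM and 12000 nM.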

Compound 3, half-maximal inhibitory concentration: > 10000 nM
Compound 3 gave a limit, no number (the forecaster's own chance of this, stated with the estimate: 10%); middle value at least 3.1-fold (0.49 log units) from the limit.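

Compound 3 gives a limit of the assay and not a number: the limit of > 10000 nM in this assay, at which 1 of the 3 values shown sits. Even so, the aromatic nitrogen proves to be a position that can move the read-out, which ethyl and cyclopropyl did not show: 1-propylbutyl in place of cyclopropyl gives an at least 3.1-fold higher number from compound 2 to compound 3 (0.49 log units; beyond the scatter), a step toward weaker inhibition. Against ethyl, the same group gives an at least 1.7-fold higher number from compound 1 to compound 3 (0.23 log units; that floor lies within the scatter), so this floor alone does not separate 1-propylbutyl from ethyl.

As far as these compounds go, how far compound 3 lies past its limit remains open, as does the size of substituent at which the read-out begins to rise. The compounds shown also do not tell how a straight propyl or butyl chain, a cyclohexyl ring or a chain ending in an amine would read at this nitrogen.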